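The source may report more compounds than this note shows. Statements on the series, on what has been measured and on what is new or still open speak of the compounds shown alone.

Compound 2 `Cc1nc(S(C)(=O)=O)ccc1Oc1ncnc(OC2CCN(C(=O)O[C@H](C)C(F)(F)F)CC2)c1F` is one of three compounds tested in a functional assay on isolated protein for inhibition of Glucose-dependent insulinotropic receptor (Homo sapiens), read by HTRF and cAMP accumulation (a lower number here means that less compound is needed, a higher number that more compound is needed for the effect), where compound 2 gives 9.2 nM. Compound 1 `Cc1nc(S(C)(=O)=O)ccc1Oc1ncnc(OC2CCN(C(=O)OC(C)(C)C(F)(F)F)CC2)c1F` gives 6.53 nM in this assay, and compound 3 `Cc1nc(S(C)(=O)=O)ccc1Oc1ncnc(OC2CCN(C(=O)C3CCCC3)CC2)c1F` gives 72.8 nM. Compound 2 stands in the middle: the step of a 1.4-fold higher number from compound 1 to compound 2 (0.15 log units; within the scatter) is within the scatter, while the step of a 7.9-fold higher number from compound 2 to compound 3 (0.90 log units; beyond the scatter) is a real move toward a weaker effect.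

Compound 4 `Cc1nc(S(C)(=O)=O)ccc1Oc1ncnc(OC2CCN(C(=O)C3(C)CC3)CC2)c1F` differs from compound 2 in one place: 1-methylcyclopropyl in place of 1-(trifluoromethyl)ethoxy on a carbonyl carbon

The most relevant earlier step is the one that also exchanged the 1-(trifluoromethyl)ethoxy on the carbonyl carbon for a carbon ring, cyclopentyl, giving a 7.9-fold higher number from compound 2 to compound 3 (0.90 log units; beyond the scatter). The parallel step an 11-fold higher number from compound 1 to compound 3 (1.05 log units; beyond the scatter) points the same way. Since compound 4 likewise replaces the 1-(trifluoromethyl)ethoxy with a carbon ring, 1-methylcyclopropyl, a higher number than that of compound 2 is expected, though the smaller ring leaves the size uncertain. Compound 4 is therefore expected to give about 45 nM, with a range of 18 nM to 120 nM. That estimate amounts to an expected 4.9-fold higher number from compound 2 to compound 4 (0.69 log units; beyond the scatter).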

Compound 4, half-maximal effective concentration: 761 nM
Compound 4: middle estimate off by 17-fold (1.23 log units), on the low side; the whole stated range lies below it.
By their numbers in this assay, from the lowest: compounds 1 and 2 (each within the scatter of the next); then compound 3; then compound 4.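

In this assay, among the compounds shown here, the earlier compounds showed only that a carbon ring on the carbonyl carbon gives a higher number than either fluorinated group, but compound 4 shows that the choice of ring also counts, with a 10-fold higher number from compound 3 to compound 4 (1.02 log units; beyond the scatter) when 1-methylcyclopropyl replaces cyclopentyl. The cost of removing the fluorinated group therefore depends strongly on what takes its place, reaching an 83-fold higher number from compound 2 to compound 4 (1.92 log units; beyond the scatter) and a 120-fold higher number from compound 1 to compound 4 (2.07 log units; beyond the scatter). No measurement available here explains this sensitivity.

The compounds shown leave open whether ring size or the methyl on the ring matters more: compound 3 and compound 4 differ in both. Cyclopropyl without the methyl, cyclobutyl and 1-methylcyclopentyl on the same carbonyl carbon would help separate these two features.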